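Chloro for acetyl on the anilide ring of compound 1

The source may report more compounds than this note shows. Statements on the series, on what has been measured and on what is new or still open speak of the compounds shown alone.

Compound 1 `CC(=O)c1ccc(NC(=O)/C=C/C(=O)N2C/C(=C\c3ccccc3)C(=O)/C(=C/c3ccccc3)C2)cc1` carries an acetyl group on the anilide ring of the shared core. In a functional assay on Molt4/C8 cells (Homo sapiens) for cytotoxicity (a higher number here means a weaker inhibitor, a lower number a stronger inhibitor), compound 1 gives 1400 nM, the highest of the three numbers recorded so far. Compound 2 `O=C(/C=C/C(=O)N1C/C(=C\c2ccc([N+](=O)[O-])cc2)C(=O)/C(=C/c2ccc([N+](=O)[O-])cc2)C1)Nc1ccccc1` gives 360 nM in this assay, and compound 3 `Cc1ccc(NC(=O)/C=C/C(=O)N2C/C(=C\c3ccc([N+](=O)[O-])cc3)C(=O)/C(=C/c3ccc([N+](=O)[O-])cc3)C2)cc1` gives 700 nM. Within the data shown here, the single one-point step among the measured compounds is a 1.9-fold higher number from compound 2 to compound 3 (0.29 log units; within the scatter), a small group entering the anilide ring on a core that differs from that of compound 1 in its two nitro groups.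

Compound 4 `O=C(/C=C/C(=O)N1C/C(=C\c2ccccc2)C(=O)/C(=C/c2ccccc2)C1)Nc1ccc(Cl)cc1` differs from compound 1 by chloro in place of acetyl on an aromatic carbon. Among the measured compounds shown here, no measured pair replaces acetyl on that carbon, so nothing recorded here bears directly on the change; the only recorded step on the same ring stayed within the scatter. On that basis the step of a 1.4-fold lower number from compound 1 to compound 4 (0.15 log units; within the scatter) is expected to stay within the scatter, with a wide range to reflect the lack of a direct precedent. Compound 4 is accordingly estimated at 1000 nM in this assay, between 350 nM and 3000 nM.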

Compound 4, half-maximal inhibitory concentration: 1800 nM
For compound 4 the middle estimate is 1.8-fold (0.26 log units) below the measured one, within the range that was stated.
By their numbers in this assay, from the lowest: compounds 2, 3, 1 and 4 (each within the scatter of the next, the first and the last beyond it).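

Among these compounds, compound 1 and compound 4 give the first direct reading at this carbon, para to a large group on the anilide ring, and the exchange is a 1.3-fold higher number from compound 1 to compound 4 (0.11 log units; within the scatter) in this assay. Three heavy atoms and a hydrogen-bond acceptor leave and one chlorine enters, yet the two numbers cannot be told apart, so on the core of compound 1 this position tolerates the exchange of acetyl for chloro without a readable shift. The earlier single step covered only methyl for hydrogen, on the core carrying two nitro groups, and no measurement on hand accounts for the present result.

Open, from the compounds shown here alone, is how an amine or a carboxylic acid on this carbon would read in this assay. Also open, going by these compounds, is whether acetyl and chloro would stay as close on the core carrying the two nitro groups.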